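Replacing cyclohexyl on the aromatic nitrogen of the series

The compounds below may be only part of what the source reports. "The series", "measured", "known", "first", "only" and "open" are said of these compounds alone.

Of the compounds shown here, three on a shared core have been measured in a functional assay on HT-29 cells (Homo sapiens) for inhibition, read by luminescence and CellTiter-Glo, with a stated time of 24 h; a lower number here means that less compound is needed, a higher number that more compound is needed for the effect. Compound 1 `CCCCCn1nc(C(=O)N[C@H]2COc3ccccc3N(C)C2=S)nc1Cc1ccccc1`, with pentyl on the aromatic nitrogen, gives 805 nM. Compound 2 `CN1C(=S)[C@@H](NC(=O)c2nc(Cc3ccccc3)n(CCCO)n2)COc2ccccc21`, with 3-hydroxypropyl there, gives 209 nM. Compound 3 `CN1C(=S)[C@@H](NC(=O)c2nc(Cc3ccccc3)n(C3CCCCC3)n2)COc2ccccc21`, with cyclohexyl there, gives 4000 nM, the highest number of the three.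

Compound 4 `CN1C(=S)[C@@H](NC(=O)c2nc(Cc3ccccc3)n(CC3CCOC3)n2)COc2ccccc21` is still to be measured. It carries (oxolan-3-yl)methyl in place of cyclohexyl on that aromatic nitrogen: (oxolan-3-yl)methyl in place of cyclohexyl on an aromatic nitrogen.

All three measured steps bear on this change, though none involves the entering group. Both steps that arrive at cyclohexyl raise the number: a 5.0-fold higher number from compound 1 to compound 3 (0.70 log units; beyond the scatter) is modest and a 19-fold higher number from compound 2 to compound 3 (1.28 log units; beyond the scatter) is large. The remaining step, a 3.9-fold lower number from compound 1 to compound 2 (0.59 log units; beyond the scatter), is modest and shows the oxygen-bearing chain of compound 2 giving the lower number. The entering group keeps a ring, as cyclohexyl does, and also holds an oxygen, as 3-hydroxypropyl does, so a result between these cases seems most likely.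

The expected step is a 6.7-fold lower number from compound 3 to compound 4 (0.82 log units; beyond the scatter), toward a lower number and of a size within the span of the two steps to cyclohexyl. For compound 4 the estimate is 600 nM, with an expected range of 180 nM to 2000 nM.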

Compound 4, half-maximal effective concentration: 4420 nM
Compound 4: middle estimate off by 7.4-fold (0.87 log units), on the low side; the whole stated range lies below it.
By their numbers in this assay, from the lowest: compound 2; then compound 1; then compounds 3 and 4 (each within the scatter of the next).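

In this assay, (oxolan-3-yl)methyl in place of cyclohexyl on this aromatic nitrogen gives (a 1.1-fold higher number from compound 3 to compound 4 (0.04 log units; within the scatter)), so the hydrogen-bond acceptor that enters with the ring leaves compound 4 within the scatter of compound 3. An oxygen in the group is therefore not enough on its own to give a number like that of compound 2, as the steps (a 21-fold higher number from compound 2 to compound 4 (1.33 log units; beyond the scatter)) and (a 5.5-fold higher number from compound 1 to compound 4 (0.74 log units; beyond the scatter)) show. Among these four compounds, the two groups with a ring both give higher numbers than the two open chains, and no compound goes against this, although two examples on each side are a thin base.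

The data offer no explanation for the gap between the ring-bearing groups and the open chains. The compounds shown leave open whether the low number of compound 2 depends on its hydroxy group or on the open chain itself, a question that a 3-methoxypropyl chain on the same nitrogen, or a hydroxy group carried on a cyclohexyl ring, would help to separate.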